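The source may hold more compounds than are shown below. What is called first, only, known or untested is meant among the compounds shown, and "the series" means these compounds.

Compound 1 `O=C(CN1CCN(c2ccncc2)CC1)Nc1nc2c(s1)CCCC2`: > 1000 nM
Compound 2 `O=C(CN1CCN(c2ccc(F)cn2)CC1)Nc1nc2c(o1)CCCC2`: 100 nM

In an assay on isolated protein for inhibition of long-chain fatty acid transport protein 1 (Homo sapiens), read by scintillation counting, with a stated time of 20 min (a higher number here means a weaker inhibitor, a lower number a stronger inhibitor), compound 1 gives only a limit, > 1000 nM, so no number places it on the scale. Its standing is summed up as the limit of > 1000 nM in this assay, at which 1 of the 2 values shown sits. Among the compounds with values here, compound 2 gives 100 nM in this assay; compound 2 differs from compound 1 in more than one place, so no step between them is counted. Compound 3 `O=C(CN1CCN(c2nccs2)CC1)Nc1nc2c(s1)CCCC2` carries 1,3-thiazol-2-yl in place of pyridin-4-yl on an amine nitrogen in a ring, that is 1,3-thiazol-2-yl in place of pyridin-4-yl on an amine nitrogen in a ring. With only a limit to start from, a move to a measurable value is expected, an at least 1.2-fold lower number from compound 1 to compound 3 (0.09 log units; that floor lies within the scatter), though the limit may be met again. Compound 3 is estimated at 800 nM, range 200 nM to 3000 nM.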

Compound 3, half-maximal inhibitory concentration: 520 nM
Compound 3: middle estimate off by 1.5-fold (0.19 log units), on the high side; low and high end bracket the measured number.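

Within the data shown here, this is the first one-place comparison at this position: 1,3-thiazol-2-yl in place of pyridin-4-yl on the amine nitrogen in a ring gives an at least 1.9-fold lower number from compound 1 to compound 3 (0.28 log units; that floor lies within the scatter). On the core of compound 1, compound 3 therefore has a measured number in this assay, 520 nM. Compound 1 holds only a limit, so the step is a floor and its true size stays unknown: the limit of > 1000 nM in this assay, at which 1 of the 3 values shown sits.

On these data alone, what a phenyl or pyrimidin-2-yl ring would give on this nitrogen stays open. So does the effect of a carboxylic acid on the 1,3-thiazol-2-yl ring.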